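A few compounds are considered here, and "the series" means these few. Any claim that something is new, unique, unknown or untested is made for them only; others in the source may bear on it.

Compound 1 `O=C1C(c2ccccc2)CC(c2ccccc2)C(=O)N1c1ccccc1` was tested in a functional assay on the whole organism (strain Swiss albino) with Mus musculus as the target, in the maximal electroshock model, with a stated time of 2 h (on this read-out lower numbers stand for an effect already at smaller amounts and higher numbers for an effect only at larger amounts of compound), where compound 1 gives 43.7 mg/kg. Compound 2 `O=C1C(c2ccccc2)CC(c2ccccc2)C(=O)N1Cc1ccccc1` carries the change (benzyl in place of phenyl on an amide-type nitrogen in a ring), and in this assay compound 2 gives 14 mg/kg, a step of a 3.1-fold lower number from compound 1 to compound 2 (0.49 log units; beyond the scatter). Compound 3 `O=C1C(c2ccccc2Cl)CC(c2ccccc2Cl)C(=O)N1c1ccccc1` has a different core; how its core differs from that of compound 1 is not broken down here. In this assay compound 3 gives 61.4 mg/kg. Compound 4 `O=C1C(c2ccccc2Cl)CC(c2ccccc2Cl)C(=O)N1Cc1ccccc1` is related to compound 3 by benzyl in place of phenyl on an amide-type nitrogen in a ring. Going by the values given here, this is the same kind of change as the one made between compound 1 and compound 2, though here the two ring atoms each bear a 2-chlorophenyl group rather than a phenyl group. The earlier step was a 3.1-fold lower number from compound 1 to compound 2 (0.49 log units; beyond the scatter). On that basis compound 4 is expected to show a step of a 3.1-fold lower number from compound 3 to compound 4 (0.49 log units; beyond the scatter). Compound 4 is therefore estimated at 20 mg/kg in this assay, within a range from 9 mg/kg to 45 mg/kg.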

Compound 4, dose for half-maximal effect: 38.3 mg/kg
For compound 4 the middle estimate is 1.9-fold (0.28 log units) below the measured one, within the range that was stated.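

In this assay benzyl in place of phenyl on the amide-type nitrogen gives a 1.6-fold lower number from compound 3 to compound 4 (0.20 log units; within the scatter) on the core with two 2-chlorophenyl groups, and set beside the earlier step the result reads: the same change on two cores in this assay, a 3.1-fold lower number (0.49 log units; beyond the scatter) from compound 1 to compound 2 and a 1.6-fold lower number (0.20 log units; within the scatter) from compound 3 to compound 4, 1.9-fold (0.29 log units) apart, within the scatter of two such steps. The two steps cannot be told apart, so these two pairs are consistent with the change carrying over from the core of compound 1 to the core of compound 3. Going by these compounds alone, they do not show that the step is the same size on both cores, as only the step on the core of compound 1 lies beyond the scatter, and they say nothing about any other core. The compounds shown leave open how a longer chain between the nitrogen and the phenyl ring would read in this assay. They also leave open what an amine on such a chain would do.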